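This account rests on a few compounds, and the source may have more. Where it says the series, first, only, none or still open, it means among the compounds named here.

Two compounds of this series have so far been taken through a functional assay on cells for agonist activity at C-X-C chemokine receptor type 4 (Homo sapiens), read by fluorescence and calcium flux, with a stated time of 90 s (on this read-out higher numbers stand for an effect only at larger amounts of compound and lower numbers for an effect already at smaller amounts), and both sit at its limit. Compound 1 `FC1(F)CCC(NCc2ccc(CN(C[C@H]3Cc4ccccc4CN3)[C@H]3CCCc4cccnc43)cc2)CC1` carries a 4,4-difluorocyclohexyl group on an amine nitrogen. In this assay compound 1 gives only a limit, > 30000 nM. Compound 2 `CC1(C)CCC(NCc2ccc(CN(C[C@H]3Cc4ccccc4CN3)[C@H]3CCCc4cccnc43)cc2)CC1` differs in one place, with 4,4-dimethylcyclohexyl in place of 4,4-difluorocyclohexyl on an amine nitrogen. In this assay compound 2 likewise gives only a limit, > 30000 nM. The step that the two limits leave unreadable from compound 1 to compound 2 cannot be read because of the limit of > 30000 nM in this assay, at which 2 of the 2 values shown sit. Compound 2 thus stands at the limit, with no number attached.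

Compound 3 `c1ccc(CNCc2ccc(CN(C[C@H]3Cc4ccccc4CN3)[C@H]3CCCc4cccnc43)cc2)nc1` is the next move: (pyridin-2-yl)methyl in place of 4,4-dimethylcyclohexyl on an amine nitrogen. Among the compounds with values here, no measured step bears on this change; the only recorded step, from compound 1 to compound 2, is itself unreadable, so neither its size nor its direction offers guidance. Compound 3 is therefore expected to fall within a wide band, with a fair chance of another limit, and the step of an at least 1.5-fold lower number from compound 2 to compound 3 (0.17 log units; that floor lies within the scatter) is an estimate only. For compound 3 the expected value in this assay is 20000 nM, between 3000 nM and 60000 nM.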

Compound 3, half-maximal effective concentration: > 30000 nM
Compound 3 gave a limit, no number; the forecaster's own chance of this, stated with the estimate: 50%; at least 1.5-fold (0.17 log units) between middle value and limit.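

No step to compound 3 from compound 1 or compound 2 can be read in this assay, because compound 3 likewise gives only a limit: the limit of > 30000 nM in this assay, at which 3 of the 3 values shown sit.

The compounds shown leave open how compound 1, compound 2 and compound 3 rank against one another, and whether any group on this amine nitrogen would give a number in this assay.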